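Trimming the Benzofuran on a Shared Nucleoside Core

This account rests on a few compounds, and the source may have more. Where it says the series, first, only, none or still open, it means among the compounds named here.

Compound 1 `COc1nc(N)nc2c1c(-c1cc3ccccc3o1)cn2[C@@H]1O[C@H](CO)[C@@H](O)[C@H]1O` gives 16700 nM in a functional assay on CEM-DNR-bulk cells (Homo sapiens), read by MTT assay, with a stated time of 72 h (a lower number here means a stronger inhibitor, a higher number a weaker inhibitor), the highest of the three numbers measured. Its nearest neighbour is compound 3 `COc1ncnc2c1c(-c1cc3ccccc3o1)cn2[C@@H]1O[C@H](CO)[C@@H](O)[C@H]1O`, which gives 10800 nM; the step of a 1.5-fold lower number from compound 1 to compound 3 (0.19 log units; within the scatter) replaces amino with hydrogen. Compound 2 `Cc1nc(N)c2c(-c3cc4ccccc4o3)cn([C@@H]3O[C@H](CO)[C@@H](O)[C@H]3O)c2n1` gives 6310 nM, a gap from compound 1 that lies beyond the scatter. Compound 4 `COc1nc(N)nc2c1c(-c1ccoc1)cn2[C@@H]1O[C@H](CO)[C@@H](O)[C@H]1O` differs from compound 1 at the group on the five-membered ring of the shared core: furan-3-yl in place of 1-benzofuran-2-yl on an aromatic carbon. Neither measured step touches this part of the structure, so no direct guide exists and no step beyond the scatter is expected. Compound 4 is therefore expected to sit close to compound 1, with a 1.5-fold higher number from compound 1 to compound 4 (0.18 log units; within the scatter) as the estimated step. The value of compound 4 is estimated at 25000 nM, within a range from 8000 nM to 80000 nM.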

Compound 4, half-maximal inhibitory concentration: > 20000 nM
Compound 4 was reported as a limit; the forecaster's own chance of this, stated with the estimate: 20%; the middle value does not contradict the limit.
By their numbers in this assay, from the lowest: compounds 2, 3 and 1 (each within the scatter of the next, the first and the last beyond it). At a limit, above all of these: compound 4.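

Compound 4 is reported in this assay only as a limit: the limit of > 20000 nM in this assay, at which 1 of the 4 values shown sits.

Furan-3-yl in place of 1-benzofuran-2-yl is the first change shown at this position on the five-membered ring of the shared core, and it gives an at least 1.1-fold higher number from compound 1 to compound 4 (0.07 log units; that floor lies within the scatter). Removing the six-membered aromatic ring therefore brings no gain here, although the true size of the step cannot be read.

The compounds shown leave open how a phenyl ring, a thiophene ring or an amine would read at this position. They also leave open whether furan-3-yl would give the same result on the core of compound 3.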